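The source may hold more compounds than are shown below. What is called first, only, known or untested is meant among the compounds shown, and "the series" means these compounds.

Series notes. In an assay on cells for antagonist activity at D(4) dopamine receptor (Homo sapiens), read by luminescence and beta-arrestin recruitment, with a stated time of 90 min (on this read-out lower numbers stand for stronger inhibition and higher numbers for weaker inhibition), compound 1 `Cc1cccc(NC(=O)CN2CCC(c3ccccc3)CC2)c1` gives 135 nM. Compound 2 `O=C(CN1CCN(c2ccccn2)CC1)Nc1cncnc1` is reported as not active in this assay, with no number attached: "not active" (no number reported). Compound 3 `O=C(CN1CCN(c2ccc(Cl)cn2)CC1)Nc1cncnc1` returns in this assay only a limit of the assay, > 100000 nM, which is the limit of > 100000 nM in this assay, at which 1 of the 3 values shown sits. Compound 2 thus stands at the inactive end of what is shown, with no measured value of its own. The step to compound 4 `Cc1cccc(NC(=O)CN2CCN(c3ccccn3)CC2)c1` is 3-methylphenyl in place of pyrimidin-5-yl on an amide-type nitrogen. The same 3-methylphenyl amide stands in compound 1 at 135 nM on a different core, so a move to lower numbers in this assay, beyond the scatter, is expected rather than none. Compound 4 is estimated at 2500 nM, within 250 nM to 30000 nM, with a fair chance that only a limit is reported.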

Compound 4, half-maximal inhibitory concentration: 313 nM
Compound 4: the middle estimate sits 8.0-fold (0.90 log units) above what was measured; low and high end bracket the measured number.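

No step can be read from compound 4 to compound 2, which carries no number, or to compound 3, which gives only a limit of the assay: the limit of > 100000 nM in this assay, at which 1 of the 4 values shown sits.

The compounds shown leave open how large the change from pyrimidin-5-yl to 3-methylphenyl is.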